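This account rests on a few compounds, and the source may have more. Where it says the series, first, only, none or still open, it means among the compounds named here.

Measured so far in a functional assay on MDA-MB-231 cells (Homo sapiens) for inhibition, read by MTT assay, with a stated time of 72 h; a higher number here means a weaker inhibitor, a lower number a stronger inhibitor:
Compound 1 `O=C(CSc1nc(Nc2ccccc2)c2ccccc2n1)Nc1cccc(F)c1` gives > 50000 nM, which is a limit of the assay rather than a number.
Compound 2 `O=C(CSc1nc(Nc2ccccc2)c2ccccc2n1)Nc1cccc(Cl)c1` gives 16500 nM.
Compound 3 `O=C(CSc1nc(Nc2ccccc2)c2ccccc2n1)Nc1ccc(Cl)c(Cl)c1` gives 14500 nM.

Compound 2 and compound 3 differ in one place: chloro in place of hydrogen on an aromatic carbon. The two values lie close together, a 1.1-fold lower number from compound 2 to compound 3 (0.06 log units; within the scatter). Compound 2 and compound 1 differ by fluoro in place of chloro on an aromatic carbon; that change gave an at least 3.0-fold higher number from compound 2 to compound 1 (0.48 log units; beyond the scatter), and the step can only be bounded because compound 1 sits at the limit of > 50000 nM in this assay, at which 1 of the 3 values shown sits.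

Compound 4 `O=C(CSc1nc(Nc2ccccc2)c2ccccc2n1)Nc1ccc(F)c(Cl)c1` has not yet been measured. It differs from compound 3 by fluoro in place of chloro on an aromatic carbon. This is the same kind of change as from compound 2 to compound 1, but not the same: there the place was meta to a large group, here it is ortho to a chloro group and para to a large group. Resting on the earlier step of an at least 3.0-fold higher number from compound 2 to compound 1 (0.48 log units; beyond the scatter), the step from compound 3 to compound 4 is expected to be a 2.1-fold higher number from compound 3 to compound 4 (0.32 log units; beyond the scatter). Compound 4 is therefore estimated at 30000 nM, with a likely range from 12000 nM to 80000 nM, and a real chance that only a limit is reported.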

Compound 4, half-maximal inhibitory concentration: 21600 nM
Beside the measured number, compound 4's estimate is 1.4-fold (0.14 log units) above it; the range from low to high includes it.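

In this assay, fluoro in place of chloro gives a 1.5-fold higher number from compound 3 to compound 4 (0.17 log units; within the scatter), and fluoro in place of hydrogen gives a 1.3-fold higher number from compound 2 to compound 4 (0.12 log units; within the scatter), so neither change moves the value beyond the scatter, whereas the change from the 3-fluorophenyl group to the 3-chloro-4-fluorophenyl group gives an at least 2.3-fold lower number from compound 1 to compound 4 (0.36 log units; beyond the scatter). The clear step seen earlier for fluoro in place of chloro therefore does not reappear clearly on the 3,4-dichlorophenyl compound, but this does not show that the change behaves differently from one compound to the other: the same change on two cores in this assay, an at least 3.0-fold higher number (0.48 log units; beyond the scatter) from compound 2 to compound 1 and a 1.5-fold higher number (0.17 log units; within the scatter) from compound 3 to compound 4; the limit leaves it open whether they differ Compound 1 gives a limit of the assay and not a number: the limit of > 50000 nM in this assay, at which 1 of the 4 values shown sits.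

The compounds shown compare only halogens on this one phenyl group, so it remains open whether a methoxy group, an amine or a carboxylic acid in the same place would move the value beyond the scatter. Going by these compounds, it also remains open what a longer chain between the shared core and the amide would do.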